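Chloro in Place of Fluoro: An Expected Step

The source may report more compounds than this note shows. Statements on the series, on what has been measured and on what is new or still open speak of the compounds shown alone.

Compound 1, `Cc1ccccc1-n1cc(-c2ccc(/C=C3\C(=O)Nc4ccccc43)cc2)nn1`: 8710 nM
Compound 2, `O=C1Nc2ccccc2/C1=C/c1ccc(-c2cn(-c3cccc(F)c3)nn2)cc1`: > 20000 nM

Compound 1 is the only one of the two with a number in a functional assay on HT-29 cells (Homo sapiens) for inhibition, read by CCK-8 assay, with a stated time of 24 h; a higher number here means a weaker inhibitor, a lower number a stronger inhibitor; compound 1 gives 8710 nM. Compound 2 reaches only a limit in this assay, > 20000 nM, which is the limit of > 20000 nM in this assay, at which 1 of the 2 values shown sits. For the measured compounds named here, the single measured step, an at least 2.2-fold higher number from compound 1 to compound 2 (0.36 log units; beyond the scatter), therefore runs to a limit and not to a number. Compound 3, `O=C1Nc2ccccc2/C1=C/c1ccc(-c2cn(-c3cccc(Cl)c3)nn2)cc1`, differs from compound 2 in one place: chloro in place of fluoro on an aromatic carbon. Going by the values given here, no measured step exchanges one halogen for another; the step just described swapped a whole substituent and so speaks only loosely to this change. With compound 2 already at a limit, a step of similar or smaller size is expected, with no clear direction beyond the scatter. For compound 3 the expected value is 20000 nM (7000 nM to 60000 nM), meaning an expected a number no higher from compound 2 to compound 3 (the limit leaves the size open).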

Compound 3, half-maximal inhibitory concentration: > 20000 nM
Compound 3: no number, only a limit (the forecaster's own chance of this, stated with the estimate: 55%); the middle value sits exactly at the limit.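

Compound 2 and compound 3 now both stand at a limit, so neither halogen gives a number and the step between them cannot be read: the limit of > 20000 nM in this assay, at which 2 of the 3 values shown sit.

With 3-chlorophenyl in place of 2-methylphenyl on the aromatic nitrogen, an at least 2.2-fold higher number from compound 1 to compound 3 (0.36 log units; beyond the scatter) appears, which repeats for a second halogen what the 3-fluorophenyl compound showed. Compound 1 therefore remains the only one of the three with a number in this assay.

Going by these compounds, whether chloro and fluoro differ at all at this place on the ring stays open, as does whether the number of compound 1 depends on the methyl group itself or on where it sits. The compounds shown also do not tell how an amine or a carboxylic acid on this phenyl ring would read.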